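Cyano in place of hydrogen on compound 2

A few compounds are considered here, and "the series" means these few. Any claim that something is new, unique, unknown or untested is made for them only; others in the source may bear on it.

In a functional assay on A549 cells (Homo sapiens) for inhibition, read by CCK-8 assay, with a stated time of 72 h, tested at 10 uM (on this read-out lower numbers stand for less inhibition of growth and higher numbers for more inhibition of growth at the one concentration tested), compound 2 `CN(C)C(=O)c1cc2cnc(Nc3ccc(NC(=O)C4(C(=O)Nc5ccccc5)CC4)cc3)nc2n1C1CCCC1` gives 88.8% and compound 1 `CN(C)C(=O)c1cc2cnc(Nc3ccc(NC(=O)C4(C(=O)Nc5ccc(Br)cc5)CC4)cc3)nc2n1C1CCCC1` gives 90.3%, so the two stand within the scatter of each other. Compound 3 `CN(C)C(=O)c1cc2cnc(Nc3ccc(NC(=O)C4(C(=O)Nc5ccc(C#N)cc5)CC4)cc3)nc2n1C1CCCC1` has cyano in place of hydrogen on an aromatic carbon, para to a large group: cyano in place of hydrogen on an aromatic carbon. Among the measured compounds shown here, the one measured step at that place, hydrogen in place of bromo, was a number 1.5 percentage points lower from compound 1 to compound 2 (within the scatter). On that basis, no change beyond the scatter is expected in this assay, and the estimated step is a number 1.8 percentage points lower from compound 2 to compound 3 (within the scatter). For compound 3 the estimate is 87%, with an expected range from 76% to 95%.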

Compound 3, percent growth inhibition at one concentration: 95%
Compound 3: the middle estimate sits 8 percentage points below what was measured; low and high end bracket the measured number.
By their numbers in this assay, from the lowest: compounds 2, 1 and 3 (each within the scatter of the next).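

In this assay the step to cyano is a number 6.2 percentage points higher from compound 2 to compound 3 (within the scatter) and the step from bromo to cyano is a number 4.7 percentage points higher from compound 1 to compound 3 (within the scatter) so the three compounds stay within the scatter of one another. At this position, para to a large group, hydrogen, bromo and now a cyano group with its triple bond therefore give no separable read-out. Nothing measured here bears on the reason for this. The compounds shown leave open whether an amine or a carboxylic acid at this place would also stay within the scatter.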